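The compounds below may be only part of what the source reports. "The series", "measured", "known", "first", "only" and "open" are said of these compounds alone.

Working notes on the naphthyloxy-acetohydrazone series. Three members have been run in an ADME assay on MT4 cells (Homo sapiens) for cytotoxicity, read by MTT assay, with a stated time of 4 days; a lower number here means that less compound is tolerated, a higher number that more compound is tolerated. Compound 1 `O=C(COc1cccc2ccccc12)N/N=C/c1ccccc1[N+](=O)[O-]` gives 12.2 ug/mL. Compound 2 `COc1ccc(/C=N/NC(=O)COc2cccc3ccccc23)cc1OC` gives 14.7 ug/mL. Compound 3 `C/C(=N\NC(=O)COc1cccc2ccccc12)c1ccc(O)cc1O` gives 59.9 ug/mL, the highest number of the three; its gap to compound 2 and its gap to compound 1 both lie beyond the scatter, while compound 1 and compound 2 sit within the scatter of each other and are not ordered here.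

The next member, compound 4 `C/C(=N\NC(=O)COc1cccc2ccccc12)c1ccc(Cl)cc1`, carries the change (4-chlorophenyl in place of 2,4-dihydroxyphenyl on a carbon with a double bond to nitrogen). For the measured compounds named here, no measured pair in the set isolates this change, so the expectation rests on the whole series: compound 1 and compound 2, which also lack hydroxyl groups on the aryl ring, give the lower numbers in this assay, and compound 3 stands alone at the top. The step expected from compound 3 to compound 4 in this assay is therefore downward, a 4.0-fold lower number from compound 3 to compound 4 (0.60 log units; beyond the scatter), beyond the scatter. Compound 4 is estimated at 15 ug/mL in this assay, with a likely range from 7 ug/mL to 40 ug/mL.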

Compound 4, half-maximal cytotoxic concentration: 4.07 ug/mL
Compound 4: the middle estimate sits 3.7-fold (0.57 log units) above what was measured; the measured number lies below the stated range.
By their numbers in this assay, from the lowest: compound 4; then compounds 1 and 2 (each within the scatter of the next); then compound 3.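

In this assay, for the compounds shown here, the first step that isolates one place is large: a 15-fold lower number from compound 3 to compound 4 (1.17 log units; beyond the scatter), so the group on the carbon with a double bond to nitrogen strongly affects the number with the rest of the molecule held constant. The change is a double one, with two hydroxyl groups leaving and a chlorine entering, so this single step cannot assign the drop to the loss of the hydroxyl groups or to the gain of the chlorine. Nothing available explains the size of the step.

Going by these compounds, it remains open whether a plain phenyl group at this place would fall nearer compound 3 or compound 4. Also open, on these data alone, is how a phenyl carrying an amine or a carboxylic acid would read in this assay.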